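The source may report more compounds than this note shows. Statements on the series, on what has been measured and on what is new or still open speak of the compounds shown alone.

In a functional assay on K562 cells (Homo sapiens) for antiproliferative activity, read by MTT assay, with a stated time of 72 h (on this read-out higher numbers stand for weaker inhibition and lower numbers for stronger inhibition), compound 1 `CCOc1ccc(Nc2c(C(=O)c3cc(OC)c(OC)c(OC)c3)sc3ccccc23)cc1` gives 200 nM and compound 2 `COc1cc(C(=O)c2sc3cc(C)ccc3c2Nc2ccc(C)cc2)cc(OC)c1OC` gives 1400 nM as its result. Compound 2 therefore holds the higher of the two numbers and is the weaker inhibitor of this pair, with a gap to compound 1 that lies beyond the scatter of repeated measurements. Compound 3 `CCOc1ccc(Nc2c(C(=O)c3cc(OC)c(OC)c(OC)c3)sc3cc(C)ccc23)cc1` differs from compound 2 in one place: ethoxy in place of methyl on an aromatic carbon (ethoxy in place of methyl on an aromatic carbon, para to a large group), so that 4-methylphenyl becomes 4-ethoxyphenyl. Going by the values given here, no measured pair shows this change on its own, so its size cannot be read directly from the data. In this assay compound 1, which carries the same (4-ethoxyphenyl)amino group, sits at 200 nM on the lower side, and that points the expectation towards stronger inhibition. The estimated change, a 4.0-fold lower number from compound 2 to compound 3 (0.60 log units; beyond the scatter) in the direction of lower numbers, is expected to lie beyond the scatter. For compound 3 the estimated value is 350 nM with an expected range from 120 nM to 1000 nM in this measurement.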

Compound 3, half-maximal inhibitory concentration: 4300 nM
The estimate for compound 3 lay 12-fold (1.09 log units) below the measured number; the measured number lies above the stated range.
By their numbers in this assay, from the lowest: compound 1; then compound 2; then compound 3.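

In this assay, going by these compounds alone, ethoxy in place of methyl on an aromatic carbon, para to a large group, gives a 3.1-fold higher number from compound 2 to compound 3 (0.49 log units; beyond the scatter), so on the methyl-bearing core of compound 3 the change from 4-methylphenyl to 4-ethoxyphenyl goes towards weaker inhibition, a direction no earlier pair could show. With the (4-ethoxyphenyl)amino group held constant, methyl in place of hydrogen on an aromatic carbon of the core gives a 22-fold higher number from compound 1 to compound 3 (1.33 log units; beyond the scatter), a large step, which shows that the low number of compound 1 does not carry over to a core with this added methyl. Nothing available gives a reason for either step.

The compounds shown leave open how 4-methylphenyl and 4-ethoxyphenyl compare on the core of compound 1, and so whether the direction of the ethoxy-for-methyl step depends on the methyl on the core. They also leave open how a methoxy group, a hydroxyl group or an amine would read at the place now held by ethoxy, and how a chlorine atom would read in place of the methyl on the core.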